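Shifting a cyano group to reach compound 4

The source may report more compounds than this note shows. Statements on the series, on what has been measured and on what is new or still open speak of the compounds shown alone.

Compound 1 `CCNC(=O)Nc1nc2cc(-c3cccnc3)c(=O)n(C(C)C)c2s1` – 0.21
Compound 2 `CCNC(=O)Nc1nc2cc(-c3cncc(F)c3)c(=O)n(C(C)C)c2s1` – 0.1
Compound 3 `CCNC(=O)Nc1nc2cc(-c3ccc(C#N)nc3)c(=O)n(C(C)C)c2s1` – 0.04

In an ADME assay on a cell-free system (plasma, Homo sapiens) (on this read-out lower numbers stand for a smaller free fraction and higher numbers for a larger free fraction), compound 3 stands lowest of the three measured compounds. Compound 4 `CCNC(=O)Nc1nc2cc(-c3cncc(C#N)c3)c(=O)n(C(C)C)c2s1` has the same atoms joined differently: 5-cyanopyridin-3-yl in place of 6-cyanopyridin-3-yl on an aromatic carbon. Substituents on the ring of compound 1 gave a 2.1-fold lower number from compound 1 to compound 2 (0.32 log units; beyond the scatter) and a 5.3-fold lower number from compound 1 to compound 3 (0.72 log units; beyond the scatter). Within the data shown here, no measured step moves a group alone, so the guidance is indirect. The closest guide is compound 2, whose 5-fluoropyridin-3-yl shares its numbering with the entering group, and the swap between the two measured groups gave a 2.5-fold lower number from compound 2 to compound 3 (0.40 log units; beyond the scatter). The expected change is a 1.5-fold higher number from compound 3 to compound 4 (0.18 log units; within the scatter), upward if anything. Compound 4 is estimated at 0.06, with an expected range of 0.03 to 0.12 in this read-out.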

Compound 4, unbound fraction: 0.1
Compound 4: the middle estimate sits 1.7-fold (0.22 log units) below what was measured; low and high end bracket the measured number.
By their numbers in this assay, from the lowest: compound 3; then compounds 2 and 4 (each within the scatter of the next); then compound 1.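

Moving the cyano group alone matters in this assay: 5-cyanopyridin-3-yl in place of 6-cyanopyridin-3-yl gives a 2.5-fold higher number from compound 3 to compound 4 (0.40 log units; beyond the scatter), so the free fraction depends on where the nitrile sits on the ring, not just on its presence. With this placement, cyano in place of fluoro gives no change at the digits printed from compound 2 to compound 4 (within the scatter), while cyano in place of hydrogen gives a 2.1-fold lower number from compound 1 to compound 4 (0.32 log units; beyond the scatter), so the two substituents cannot be told apart here. Nothing available explains the effect of the shift. On these data alone, whether an amine or a carboxylic acid in place of the cyano group of compound 4 would shift the number remains open.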